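Benzyl to allyl: from compound 2 to compound 4

The source may hold more compounds than are shown below. What is called first, only, known or untested is meant among the compounds shown, and "the series" means these compounds.

Measured so far:
- compound 1 `C=CCNC1=C2C[C@@H](C)C[C@H](OC)[C@H](OC(=O)CCN)[C@@H](C)/C=C(\C)[C@H](OC(N)=O)[C@@H](OC)/C=C\C=C(/C)C(=O)NC(=CC1=O)C2=O`, in a functional assay on SK-BR-3 cells (Homo sapiens) for cytotoxicity, read by CellTiter-Glo, with a stated time of 72 h (on this read-out lower numbers stand for stronger inhibition and higher numbers for weaker inhibition), compound 1 gives 1800 nM
- compound 2 `CO[C@H]1C[C@H](C)CC2=C(NCCN(C)C)C(=O)C=C(NC(=O)/C(C)=C/C=C\[C@H](OC)[C@@H](OC(N)=O)/C(C)=C/[C@H](C)/C1=N\OCc1ccccc1)C2=O`, in this assay compound 2 gives 480 nM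
- compound 3 `C=CCNC1=C2C[C@@H](C)C[C@H](OC)C(=O)[C@@H](C)/C=C(\C)[C@H](OC(N)=O)[C@@H](OC)/C=C\C=C(/C)C(=O)NC(=CC1=O)C2=O`, in this assay compound 3 gives 450 nM

Compound 2 holds the second highest of the three numbers. Its nearest neighbour is compound 3, whose value sits within the usual scatter of that of compound 2, so the two cannot be ordered. Its furthest neighbour is compound 1, whose value lies beyond the scatter and is the higher, weaker one. Within the data shown here, none of the three pairs differs in a single place, so no step of known size is available from the measured set.

Compound 4 `C=CCO/N=C1/[C@@H](OC)C[C@H](C)CC2=C(NCCN(C)C)C(=O)C=C(NC(=O)/C(C)=C/C=C\[C@H](OC)[C@@H](OC(N)=O)/C(C)=C/[C@@H]1C)C2=O` is the next compound to be measured in this assay. It differs from compound 2 as follows: vinyl in place of phenyl on a saturated chain carbon bound to an oxygen. The change keeps the same count of donors and acceptors and the same absence of charge; only the size of the group on the saturated chain carbon bound to an oxygen shrinks. Among the measured compounds shown here, with no measured step touching this place, the expectation rests on the change being small and peripheral: no step beyond the scatter in this assay, in either direction.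

The expected step is a 1.1-fold higher number from compound 2 to compound 4 (0.06 log units; within the scatter), which amounts to none beyond the scatter.

Compound 4 is estimated at 550 nM, with a range from 220 nM to 1400 nM.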

Compound 4, half-maximal inhibitory concentration: 400 nM
Compound 4: middle estimate off by 1.4-fold (0.14 log units), on the high side; the measured number falls inside the stated range.
By their numbers in this assay, from the lowest: compounds 4, 3 and 2 (each within the scatter of the next); then compound 1.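

In this assay, among these compounds, the first step at this place, a 1.2-fold lower number from compound 2 to compound 4 (0.08 log units; within the scatter), gives no readable change when vinyl replaces phenyl on a saturated chain carbon bound to an oxygen. The series can therefore lose the six-membered aromatic ring here, going from benzyloxy to allyloxy, without a shift beyond the scatter, so the aromatic ring is not needed to hold the number at this level in this cell read-out. No measurement shown bears on why the two groups read alike.

The compounds shown leave open how an amine or a carboxylic acid on this chain, or a longer chain, would read in this assay. Also open, from the compounds shown here alone, is whether the same replacement would read alike elsewhere, as compound 1 and compound 3 each differ from compound 4 in more than one place.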